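The source may hold more compounds than are shown below. What is called first, only, known or untested is meant among the compounds shown, and "the series" means these compounds.

Measured so far in a functional assay on U-87MG ATCC cells for antiproliferative activity against U-87 MG (Homo sapiens), read by MTT assay, with a stated time of 48 h, tested at 50 uM; on this read-out lower numbers stand for a stronger effect and higher numbers for a weaker effect at the one concentration tested: compound 1 `COc1ccc(-c2nc(C)c(C(=O)CSc3nc(N)c(C#N)c(-c4ccc(Cl)cc4)n3)s2)cc1` gives 23.1%; compound 2 `COc1ccc(-c2nc(SCC(=O)c3sc(-c4ccccc4)nc3C)[nH]c(=O)c2C#N)cc1` gives 52.1%; compound 3 `COc1ccc(-c2nc(C)c(C(=O)CSc3nc(-c4ccc(OC)cc4)c(C#N)c(=O)[nH]3)s2)cc1` gives 32.6%.

Compound 2 and compound 3 differ in one place, (hydrogen in place of methoxy on an aromatic carbon), and that step was a number 19.5 percentage points higher from compound 3 to compound 2 (beyond the scatter). Compound 4 `Cc1nc(-c2ccccc2)sc1C(=O)CSc1nc(N)c(C#N)c(-c2ccc(Cl)cc2)n1` has not yet been measured; it arises from compound 1 by the same change, (hydrogen in place of methoxy on an aromatic carbon), applied on a different core. The difference between the core of compound 1 and the core of compound 3 is not broken down here. Compound 1 and compound 3 give numbers within the scatter of each other, while compound 2 stands beyond the scatter from compound 1. For the measured compounds named here, because the only measured instance of this change a number 19.5 percentage points higher from compound 3 to compound 2 (beyond the scatter) weakened the effect, a step in the same direction is expected for compound 4, a number 14.9 percentage points higher from compound 1 to compound 4 (beyond the scatter), though with less confidence since the core differs. For compound 4 the estimate is 38%, expected to fall between 22% and 55%.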

Compound 4, a percentage reported as activity, at one concentration (the size of the read-out at that concentration, not a potency): 44.3%
The estimate for compound 4 lay 6.3 percentage points below the measured number, and the stated range covers the measured number.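

Replacing methoxy with hydrogen on the 4-methoxyphenyl group weakened the effect on the second core too, in this assay, giving a number 21.2 percentage points higher from compound 1 to compound 4 (beyond the scatter). The change carried over between these two cores at a similar size: the same change on two cores in this assay, a number 19.5 percentage points higher (beyond the scatter) from compound 3 to compound 2 and a number 21.2 percentage points higher (beyond the scatter) from compound 1 to compound 4, 1.7 percentage points apart, within the scatter of two such steps. For the compounds shown here, this rests on only two pairs of compounds at a single concentration, so it does not show that the change would behave the same way on other cores, nor does it explain why the methoxy group matters.

The compounds shown leave open what other groups would do in the same place, such as an ethoxy group, a fluorine atom or an amine.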